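This account rests on a few compounds, and the source may have more. Where it says the series, first, only, none or still open, it means among the compounds named here.

In an ADME assay on HeLa cells (Homo sapiens) for cytotoxicity (a lower number here means that less compound is tolerated, a higher number that more compound is tolerated), compound 3 `CC(=O)OC[C@H]1O[C@@H](n2cc(-c3cc(C)no3)c(=O)[nH]c2=O)C[C@@H]1OC(C)=O` gives 3000 nM, level with compound 1 `CCCc1cc(-c2cn([C@H]3C[C@H](OC(C)=O)[C@@H](COC(C)=O)O3)c(=O)[nH]c2=O)on1` at 3000 nM and compound 2 `CCCCCc1cc(-c2cn([C@H]3C[C@H](OC(C)=O)[C@@H](COC(C)=O)O3)c(=O)[nH]c2=O)on1` at 3000 nM. Compound 4 `CC(=O)OC[C@H]1O[C@@H](n2cc(-c3cc(-c4ccc(C(C)C)cc4)no3)c(=O)[nH]c2=O)C[C@@H]1OC(C)=O` differs from compound 3 by a single change: 4-isopropylphenyl in place of methyl on an aromatic carbon. Among the measured compounds shown here, three measured steps bear on it, all among saturated chains: no change at the digits printed from compound 1 to compound 2 (within the scatter), no change at the digits printed from compound 1 to compound 3 (within the scatter) and no change at the digits printed from compound 2 to compound 3 (within the scatter). For the measured compounds named here, none of the measured compounds carries an aromatic ring at that carbon, so the evidence is indirect. No shift beyond the scatter is therefore expected in this assay, and the estimated step is no change at the digits printed from compound 3 to compound 4 (within the scatter). The value expected for compound 4 is 3000 nM, with an estimated range of 1200 nM to 7500 nM.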

Compound 4, half-maximal cytotoxic concentration: 3000 nM
Compound 4: middle estimate and measured number agree at the digits printed; low and high end bracket the measured number.
By their numbers in this assay, from the lowest: compounds 1, 2, 3 and 4 (each within the scatter of the next).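

In this assay, among the compounds shown here, an aromatic ring stands at this carbon for the first time, and 4-isopropylphenyl in place of methyl gives no change at the digits printed from compound 3 to compound 4 (within the scatter). Set against the saturated chains, it gives no change at the digits printed from compound 2 to compound 4 (within the scatter) and no change at the digits printed from compound 1 to compound 4 (within the scatter), so across these four compounds the read-out does not separate an aromatic ring from a chain at this carbon. Nothing available explains this result.

On these data alone, whether an amine or a carboxylic acid at this carbon would move the number stays open. So does the effect of either group on the phenyl ring.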